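The source may report more compounds than this note shows. Statements on the series, on what has been measured and on what is new or still open speak of the compounds shown alone.

In an ADME assay on microsomes from liver (Homo sapiens) for metabolic stability, using NADPH, with a stated time of 10 min (on this read-out higher numbers stand for a more stable compound and lower numbers for a less stable compound), compound 3 (`c1cnc2c(c1)CN[C@@H](CN(CCCCNC1COC1)[C@H]1CCCc3cccnc31)C2`) gives 97%, within the scatter of compound 1 (`CN(C)CCCCN(C[C@H]1Cc2ncccc2CN1)[C@H]1CCCc2cccnc21`) at 100% and clearly higher than compound 2 (`CCN(CC)CCCCN(C[C@H]1Cc2ncccc2CN1)[C@H]1CCCc2cccnc21`) at 80%. Compound 4 (`c1cnc2c(c1)CN[C@@H](CN(CCCCN(C1COC1)C1COC1)[C@H]1CCCc3cccnc31)C2`) differs from compound 3 by oxetan-3-yl in place of hydrogen on an amine nitrogen. Two measured steps change the group at this same chain end. Replacing dimethylamino with (oxetan-3-yl)amino gave a number 3 percentage points lower from compound 1 to compound 3 (within the scatter), while replacing it with diethylamino gave a number 20 percentage points lower from compound 1 to compound 2 (beyond the scatter). Neither step is the same change as this one, so they guide the expectation only loosely. No change beyond the scatter is expected, and the estimated step is a number 6 percentage points lower from compound 3 to compound 4 (within the scatter). Compound 4 is estimated at 91%, with an expected range of 77% to 100%.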

Compound 4, percent of the compound remaining: 62%
For compound 4 the middle estimate is 29 percentage points above the measured one; measured number outside the range, below it.
By their numbers in this assay, from the lowest: compound 4; then compound 2; then compounds 3 and 1 (each within the scatter of the next).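

In this assay, putting oxetan-3-yl in place of hydrogen on this amine nitrogen gives a number 35 percentage points lower from compound 3 to compound 4 (beyond the scatter) at this chain end, so this change is not neutral here. The same compound also stands apart from the diethylamino and dimethylamino ends, with a number 18 percentage points lower from compound 2 to compound 4 (beyond the scatter) and a number 38 percentage points lower from compound 1 to compound 4 (beyond the scatter) as the two steps. Nothing measured here says why the number falls.

As far as these compounds go, whether the fall belongs to oxetan-3-yl itself or to any second group on this nitrogen stays open. A methyl group in its place on that nitrogen would help separate the two.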